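Chloro in place of fluoro: expectations for compound 3

The source may hold more compounds than are shown below. What is called first, only, known or untested is meant among the compounds shown, and "the series" means these compounds.

Among the measured compounds shown here, in a functional assay on FM3A cells (Mus musculus) for antiproliferative activity, with a stated time of 48 h (on this read-out lower numbers stand for stronger inhibition and higher numbers for weaker inhibition), compound 2 `Nc1ccc(/C=C/C(=O)c2ccc(F)cc2)cc1` gives 185000 nM, the higher of the two numbers so far. Compound 1 `C=C(Br)C(=O)Nc1ccc(/C=C/C(=O)c2ccc(Cl)cc2)cc1` gives 1300 nM, far lower and beyond the scatter, but it differs from compound 2 in more than one place. Compound 3 `Nc1ccc(/C=C/C(=O)c2ccc(Cl)cc2)cc1` carries chloro in place of fluoro on an aromatic carbon, para to a large group: chloro in place of fluoro on an aromatic carbon. For the measured compounds named here, no measured pair shows this change alone. In this assay a step within the scatter, leaning toward stronger inhibition, is expected, with an estimated 1.9-fold lower number from compound 2 to compound 3 (0.27 log units; within the scatter). For compound 3 the expected value is 100000 nM, with an estimated range of 35000 nM to 220000 nM.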

Compound 3, half-maximal inhibitory concentration: 178000 nM
Estimate against measurement, compound 3: 1.8-fold (0.25 log units) below; the range from low to high includes it.
By their numbers in this assay, from the lowest: compound 1; then compounds 3 and 2 (each within the scatter of the next).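

In this assay, chloro in place of fluoro on this aromatic carbon gives a 1.0-fold lower number from compound 2 to compound 3 (0.02 log units; within the scatter) and so separates compound 2 and compound 3 by no more than the scatter. The large step sits on the nitrogen instead, where hydrogen in place of (1-bromoethenyl)carbonyl gives a 140-fold higher number from compound 1 to compound 3 (2.14 log units; beyond the scatter) with chloro held constant. Nothing here bears on the reason for either step. Open, as far as these compounds go, are whether a methoxy group on the same aromatic carbon would also stay within the scatter, and how much of the nitrogen step an acetyl group would retain.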